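The source may report more compounds than this note shows. Statements on the series, on what has been measured and on what is new or still open speak of the compounds shown alone.

Compound 1, `COC(=O)[C@@]1(C)CC[C@@H]2C3=C1CC[C@@H](C)[C@]3(C)Cc1c2[nH]c2ccc(C)cc12`, is the starting point of this set. In a functional assay on HBL-100 cells (Homo sapiens) for inhibition, read by sulforhodamine B assay, with a stated time of 48 h (a lower number here means a stronger inhibitor of growth, a higher number a weaker inhibitor of growth), compound 1 gives 11000 nM. Compound 2, `COC(=O)[C@@]1(C)CC[C@@H]2C3=C1CC[C@@H](C)[C@]3(C)Cc1c2[nH]c2ccc(Br)cc12`, carries the change bromo in place of methyl on an aromatic carbon relative to compound 1, and in this assay compound 2 gives 16000 nM; the step is a 1.5-fold higher number from compound 1 to compound 2 (0.16 log units; within the scatter). Compound 3, `COC(=O)[C@@]1(C)CC[C@@H]2C3=C1CC[C@@H](C)[C@]3(C)Cc1c2[nH]c2c(C)cccc12`, shares the same atoms with compound 1 joined differently, and the difference between the two cores is not broken down here. In this assay compound 3 gives 13000 nM, a number that sits within the scatter of both compound 1 and compound 2, so no order among the three can be drawn.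

Compound 4, `COC(=O)[C@@]1(C)CC[C@@H]2C3=C1CC[C@@H](C)[C@]3(C)Cc1c2[nH]c2c(Br)cccc12`, has not yet been measured. It differs from compound 3 by bromo in place of methyl on an aromatic carbon. Among the measured compounds shown here, this is the same kind of change as the one from compound 1 to compound 2, though the surroundings differ: in compound 2 the bromo sits meta to a fused ring and para to a fused ring, while in compound 4 it sits ortho to a fused ring and meta to a fused ring. For the measured compounds named here, the step from compound 3 to compound 4 is expected to be a 1.4-fold higher number from compound 3 to compound 4 (0.14 log units; within the scatter), resting on the only measured example of this kind of change, because a 1.5-fold higher number from compound 1 to compound 2 (0.16 log units; within the scatter) was within the scatter. Compound 4 is therefore expected to give about 18000 nM in this assay, with a likely range from 9000 nM to 36000 nM.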

Compound 4, concentration for 50% growth inhibition: 26000 nM
Estimate against measurement, compound 4: 1.4-fold (0.16 log units) below; measured number inside the range.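

In this assay, bromo in place of methyl on an aromatic carbon gives a 2.0-fold higher number from compound 3 to compound 4 (0.30 log units; within the scatter), and set beside the earlier step, the change reads alike on the two cores: the same change on two cores in this assay, a 1.5-fold higher number (0.16 log units; within the scatter) from compound 1 to compound 2 and a 2.0-fold higher number (0.30 log units; within the scatter) from compound 3 to compound 4, 1.4-fold (0.14 log units) apart, within the scatter of two such steps. So far as these two pairs go, the change carries from one core to the other without a difference that can be told from the scatter, whether the bromo sits meta to a fused ring and para to a fused ring, or ortho to a fused ring and meta to a fused ring. This does not show that the change has any real effect, since neither step stands beyond the scatter, nor does it establish a rule, since it rests on two pairs and cannot separate the place of the bromo from noise.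

The compounds shown carry only methyl or bromo on the aromatic ring and all keep the same methyl ester, so it remains open how a fluoro, a methoxy or an amine would read at these places. Going by these compounds, it also remains open how a carboxylic acid in place of the ester would read, and whether any such change would move the number beyond the scatter.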